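The source may report more compounds than this note shows. Statements on the series, on what has been measured and on what is new or still open speak of the compounds shown alone.

Measured so far in a functional assay (aorta) with Rattus norvegicus as the target; on this read-out higher numbers stand for an effect only at larger amounts of compound and lower numbers for an effect already at smaller amounts:
Compound 1 `COc1ccccc1NC(=O)NC1CC(C)(C)Oc2ccc(Cl)cc21`: in this assay compound 1 gives only the limit > 10000 nM.
Compound 2 `CC1(C)CC(NC(=O)Nc2ccccc2Cl)c2cc(Cl)ccc2O1`: in this assay compound 2 gives only the limit > 300000 nM.
Compound 3 `CC1(C)CC(NC(=O)Nc2cccc(Cl)c2)c2cc(Cl)ccc2O1`: in this assay compound 3 gives only the limit > 30000 nM.

Compound 3 thus stands at a limit, not a number, and the same holds for the other two; the three sit at the limit of > 10000 nM in this assay, at which 1 of the 3 values shown sits, the limit of > 30000 nM in this assay, at which 1 of the 3 values shown sits, and (the limit of > 300000 nM in this assay, at which 1 of the 3 values shown sits). The steps a step that the two limits leave unreadable from compound 1 to compound 2, a step that the two limits leave unreadable from compound 1 to compound 3 and a step that the two limits leave unreadable from compound 2 to compound 3 are each unreadable between two limits. Compound 4 `CC1(C)CC(NC(=O)Nc2ccc(Cl)cc2)c2cc(Cl)ccc2O1` differs from compound 3 by 4-chlorophenyl in place of 3-chlorophenyl on an amide-type nitrogen. The nearest step, a step that the two limits leave unreadable from compound 2 to compound 3, also exchanges the chlorophenyl on the amide-type nitrogen and gives no readable size, so no direction can be expected beyond the scatter. Compound 4 is estimated at 50000 nM, range 15000 nM to 300000 nM, most likely again a limit. The expected step that the limit leaves unreadable from compound 3 to compound 4 is a guess of no change.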

Compound 4, half-maximal effective concentration: > 300000 nM
Compound 4 gave a limit, no number; the forecaster's own chance of this, stated with the estimate: 80%; middle value at least 6.0-fold (0.77 log units) from the limit.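

Among these compounds, compound 4 gives only a limit in this assay, as do compound 1, compound 2 and compound 3, so no step from compound 4 to these compounds can be read. The compounds shown leave open how the chlorophenyl isomers rank in this assay.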